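The source may hold more compounds than are shown below. What is called first, only, known or untested is meant among the compounds shown, and "the series" means these compounds.

Measured so far in a functional assay on the whole organism (Tail, strain ICR) with Mus musculus as the target, in the tail flick test, with a stated time of 150 min, at a dose of 25 umol/kg by the oral route; on this read-out lower numbers stand for a weaker effect and higher numbers for a stronger effect at the one dose given:
compound 1 `O=C(CN(c1nc(Cl)nc2[nH]cnc12)C1CC1)N[C@@H](CO)C(=O)OCc1ccccc1` gives 27.9%
compound 2 `O=C(O)[C@@H]1CCCN1C(=O)CN(c1nc(Cl)nc2[nH]cnc12)C1CC1` gives 7.29%
compound 3 `CC[C@H](C)[C@H](NC(=O)CN(c1nc(Cl)nc2[nH]cnc12)C1CC1)C(=O)O` gives 6.71%

Compound 3 gives the lowest of the three numbers. Its value and that of compound 2 lie within the scatter of each other, so no order between the two can be read; compound 1 stands beyond the scatter above both.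

Compound 4 `O=C(CN(c1nc(Cl)nc2[nH]cnc12)C1CC1)N[C@@H](CO)C(=O)O` is not yet measured. It differs from compound 3 in one place: hydroxymethyl in place of sec-butyl on a saturated chain carbon bound to an amide-type nitrogen and a carbonyl carbon. Going by the values given here, no step between measured compounds is on record, so the expectation rests on the values alone. Because compound 2 sits at 7.29% and compound 3 at 6.71%, a small change is expected. The step is expected to be a number 3.3 percentage points higher from compound 3 to compound 4 (within the scatter), within the scatter and in no clear direction. Compound 4 is estimated at 10%, between 0% and 24%.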

Compound 4, a percentage reported as activity, at one dose (the size of the read-out at that dose, not a potency): 18.8%
The estimate for compound 4 lay 8.8 percentage points below the measured number; measured number inside the range.
By their numbers in this assay, from the lowest: compounds 3 and 2 (each within the scatter of the next); then compounds 4 and 1 (each within the scatter of the next).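

In this assay, hydroxymethyl in place of sec-butyl on the saturated chain carbon gives a number 12.1 percentage points higher from compound 3 to compound 4 (beyond the scatter) and so moves the number beyond the scatter, while (1-carboxy-2-hydroxyethyl)amino in place of 2-carboxypyrrolidin-1-yl gives a number 11.5 percentage points higher from compound 2 to compound 4 (beyond the scatter) as a second such step. Hydrogen in place of benzyl on the oxygen gives a number 9.1 percentage points lower from compound 1 to compound 4 (within the scatter) and so leaves the free carboxylic acid and the benzyl ester unseparated. Nothing on record explains these steps.

Open, going by these compounds, is how a methyl or aminomethyl group on this carbon would read. Also open, on these data alone, is whether a methyl ester would track the benzyl ester.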